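This account rests on a few compounds, and the source may have more. Where it says the series, first, only, none or still open, it means among the compounds named here.

In a functional assay on B16-F10 cells (Mus musculus) for antiproliferative activity, read by MTT assay, with a stated time of 48 h (a lower number here means a stronger inhibitor, a higher number a weaker inhibitor), the three measured compounds gave the following:
compound 1 `COc1ccc(/C=C/c2cc(OC)cc(OC)c2/C=C/C(=O)c2ccccc2)cc1`: 3.7 ug/mL;
compound 2 `COc1ccc(/C=C/c2cc(OC)cc(OC)c2/C=C/C(=O)c2ccccc2C)cc1`: 6.1 ug/mL;
compound 3 `COc1ccc(/C=C/c2cc(OC)cc(OC)c2/C=C/C(=O)c2ccc(OC)cc2)cc1`: 5.8 ug/mL.

Compound 1 has the lowest number of the three, though both other compounds lie within the scatter of it. Compound 4 `COc1ccc(/C=C/c2cc(OC)cc(OC)c2/C=C/C(=O)c2ccc(C)cc2C)cc1` differs from compound 1 by 2,4-dimethylphenyl in place of phenyl on a carbonyl carbon. Going by the values given here, two measured steps bear on this change: a 1.6-fold higher number from compound 1 to compound 2 (0.22 log units; within the scatter), a methyl in place of hydrogen on an aromatic carbon, and a 1.6-fold higher number from compound 1 to compound 3 (0.20 log units; within the scatter). Both stayed within the scatter, as did a 1.1-fold lower number from compound 2 to compound 3 (0.02 log units; within the scatter). For compound 4 a small rise in this assay is therefore expected, about a 1.6-fold higher number from compound 1 to compound 4 (0.21 log units; within the scatter), not clearly beyond the scatter. The estimate for compound 4 is 6 ug/mL, between 3 ug/mL and 12 ug/mL.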

Compound 4, half-maximal inhibitory concentration: 4 ug/mL
Estimate against measurement, compound 4: 1.5-fold (0.18 log units) above; the range from low to high includes it.
By their numbers in this assay, from the lowest: compounds 1, 4, 3 and 2 (each within the scatter of the next).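

In this assay, 2,4-dimethylphenyl in place of phenyl on the carbonyl carbon gives a 1.1-fold higher number from compound 1 to compound 4 (0.03 log units; within the scatter), so a ring with two methyl groups at this position stays as close to compound 1 as the singly substituted rings do. The added methyl gives a 1.5-fold lower number from compound 2 to compound 4 (0.18 log units; within the scatter), and the exchange of 4-methoxyphenyl gives a 1.5-fold lower number from compound 3 to compound 4 (0.16 log units; within the scatter), which leaves all four compounds within the scatter of one another. No measurement on hand accounts for these steps.

On these data alone, whether an amine or a carboxylic acid on this ring would move the number beyond the scatter remains open.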